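Bromocatechol ethers: methyl to ethyl on the ether chain

This account rests on a few compounds, and the source may have more. Where it says the series, first, only, none or still open, it means among the compounds named here.

Three measured compounds share the read-out of a functional assay on HCT-116 cells (Homo sapiens) for cytotoxicity, read by MTT assay, with a stated time of 96 h; on this read-out higher numbers stand for weaker inhibition and lower numbers for stronger inhibition. Compound 1 `COCc1cc(Br)c(O)c(O)c1Br` gives 3480 nM in this assay. Compound 2 `CCOCc1cc(O)c(O)c(Br)c1Br` gives 2510 nM in this assay, and compound 3 `COCc1cc(O)c(O)c(Br)c1Br` gives 14100 nM in this assay. The numbers of compound 1 and compound 2 lie within the scatter of each other, so no order is claimed between them; the number of compound 1 stands beyond the scatter from that of compound 3.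

Compound 3 and compound 2 differ by one change, (methyl in place of hydrogen on a saturated chain carbon bound to an oxygen on a saturated carbon), which produced a 5.6-fold lower number from compound 3 to compound 2 (0.75 log units; beyond the scatter). Compound 1 and compound 3 are built from the same atoms joined differently; the difference between the two cores is not broken down here.

Compound 4 `CCOCc1cc(Br)c(O)c(O)c1Br` has not been measured in this assay. It differs from compound 1 by methyl in place of hydrogen on a saturated chain carbon bound to an oxygen on a saturated carbon. The place of this change is described in the same words as for the change from compound 3 to compound 2, so it is the same change made on a second core. For the measured compounds named here, only one earlier instance exists, and the two cores differ in a way not broken down, so the expected step is set smaller than the earlier one. The step from compound 1 to compound 4 is expected to be a 3.5-fold lower number from compound 1 to compound 4 (0.54 log units; beyond the scatter), resting on compound 3 to compound 2 having given a 5.6-fold lower number from compound 3 to compound 2 (0.75 log units; beyond the scatter). Compound 4 is accordingly estimated at 1000 nM, with a range from 350 nM to 2800 nM.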

Compound 4, half-maximal inhibitory concentration: 1540 nM
For compound 4 the middle estimate is 1.5-fold (0.19 log units) below the measured one; the range from low to high includes it.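

In this assay, replacing methoxymethyl with ethoxymethyl on the core of compound 1 gives a 2.3-fold lower number from compound 1 to compound 4 (0.35 log units; beyond the scatter), which is in the same direction as the earlier step on the core of compound 3. The two steps are not separated by more than the scatter expected of two such steps, so the change carries from one core to the other in direction, and no difference in its size between the cores can be claimed: the same change on two cores in this assay, a 5.6-fold lower number (0.75 log units; beyond the scatter) from compound 3 to compound 2 and a 2.3-fold lower number (0.35 log units; beyond the scatter) from compound 1 to compound 4, 2.5-fold (0.40 log units) apart, within the scatter of two such steps. This rests on one matched pair for each core, so it supports a shared direction for these two cores only; it gives no fixed size for the step, no rule for other cores in the series and no explanation of why the numbers fall.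

Still open, on these data alone, is whether the numbers in this assay keep falling with a longer chain such as propoxymethyl or a branched one such as isopropoxymethyl, or whether the trend stops at ethoxymethyl on either core. Also open is how each core would respond if the ether chain carried an amine or a carboxylic acid instead, since the compounds shown cover only methoxymethyl and ethoxymethyl.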